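The source may hold more compounds than are shown below. What is called first, only, known or untested is meant among the compounds shown, and "the series" means these compounds.

Measured so far in a functional assay on MIA PaCa-2 cells (Homo sapiens) for inhibition, read by MTT assay, with a stated time of 3 days; on this read-out higher numbers stand for weaker inhibition and lower numbers for stronger inhibition:
- compound 1 `O=C([C@@H]1CCCN(S(=O)(=O)c2ccc(S(=O)(=O)N3CC[C@@H](O)C3)cc2)C1)N1CCC(F)(F)CC1`: 135 nM
- compound 2 `CCN(CC)S(=O)(=O)c1ccc(S(=O)(=O)N2CCC[C@@H](C(=O)N3CCC(OC)CC3)C2)cc1`: 50 nM

Compound 2 has the lower number of the two, and the gap to compound 1 lies beyond the usual scatter. Compound 3 `CCN(CC)S(=O)(=O)c1ccc(S(=O)(=O)N2CCC[C@@H](C(=O)N3CCC(C(F)(F)F)CC3)C2)cc1` differs from compound 2 in one place: trifluoromethyl in place of methoxy on a saturated ring carbon, with trifluoromethyl in place of methoxy on a saturated ring carbon. For the measured compounds named here, no measured pair isolates a change at one place. Compound 2 differs from compound 1 in more than one place, so compound 1 at 135 nM cannot separate this change. In this assay, a modest move towards a higher number is expected, probably not beyond the scatter. The estimated change is a 1.4-fold higher number from compound 2 to compound 3 (0.15 log units; within the scatter). For compound 3, the estimated value is 70 nM, with an expected range of 25 nM to 200 nM.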

Compound 3, half-maximal inhibitory concentration: 110 nM
For compound 3 the middle estimate is 1.6-fold (0.20 log units) below the measured one, within the range that was stated.
By their numbers in this assay, from the lowest: compound 2; then compounds 3 and 1 (each within the scatter of the next).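

In this assay, for the compounds shown here, replacing 4-methoxypiperidin-1-yl with 4-(trifluoromethyl)piperidin-1-yl gives a 2.2-fold higher number from compound 2 to compound 3 (0.34 log units; beyond the scatter) as the first change isolated at one place. This ring carbon, three ring bonds from the ring nitrogen, is therefore not indifferent to the group it carries: methoxy gives the lower number of this pair, and the modest size of the step shows that trifluoromethyl is tolerated there without a large loss. No measurement on these compounds accounts for the step.

Still open, on these data alone, is how a hydroxyl, a primary amine, a carboxylic acid or a longer chain such as ethoxy would behave on this ring carbon. Also open, as far as these compounds go, is whether the same change would give a similar step on the core of compound 1.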